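The source may report more compounds than this note shows. Statements on the series, on what has been measured and on what is new or still open speak of the compounds shown alone.

Working notes on the series. Compound 1 `Cc1cccc(OS(=O)(=O)c2ccc(N3CCN(C)C3=O)cc2)c1` gives 4300 nM in a functional assay on HT-29 cells (Homo sapiens) for antiproliferative activity, read by sulforhodamine B assay, with a stated time of 48 h; on this read-out higher numbers stand for weaker inhibition and lower numbers for stronger inhibition. Compound 2 `COc1cccc(OS(=O)(=O)c2ccc(N3CCN(C)C3=O)cc2)c1` gives 2500 nM in this assay; the change is methoxy in place of methyl on an aromatic carbon, and the step is a 1.7-fold lower number from compound 1 to compound 2 (0.24 log units; within the scatter). Compound 3 `Cc1ccc(OS(=O)(=O)c2ccc(N3CCN(C)C3=O)cc2)cc1` carries a different core, the difference being (4-methylphenyl in place of 3-methylphenyl on an oxygen). For compound 3 this assay reports only a limit, > 100000 nM. The corresponding steps are an at least 23-fold higher number from compound 1 to compound 3 (1.36 log units; beyond the scatter) and an at least 40-fold higher number from compound 2 to compound 3 (1.60 log units; beyond the scatter). Compound 4 `COc1ccc(OS(=O)(=O)c2ccc(N3CCN(C)C3=O)cc2)cc1` is not yet measured; its difference from compound 3 is methoxy in place of methyl on an aromatic carbon, the same kind of change as from compound 1 to compound 2, but made para to a large group rather than meta to a large group. The expected step is a step that the limit leaves unreadable from compound 3 to compound 4, resting on the step of the earlier pair being within the scatter and on compound 3 sitting at the limit (the limit of > 100000 nM in this assay, at which 1 of the 3 values shown sits). Compound 4 is estimated at 150000 nM, between 40000 nM and 600000 nM.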

Compound 4, half-maximal inhibitory concentration: > 100000 nM
Compound 4: only a limit was reported; the forecaster's own chance of this, stated with the estimate: 70%; the middle value lies beyond the limit too.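

In this assay compound 4 gives only a limit, > 100000 nM, and compound 3 also gives only a limit, so the step between them cannot be read: the limit of > 100000 nM in this assay, at which 2 of the 4 values shown sit.

The readable steps concern the change of aryl group on the oxygen, with an at least 40-fold higher number from compound 2 to compound 4 (1.60 log units; beyond the scatter) and an at least 23-fold higher number from compound 1 to compound 4 (1.36 log units; beyond the scatter). The methoxy-for-methyl change, with a 1.7-fold lower number from compound 1 to compound 2 (0.24 log units; within the scatter), is therefore neither confirmed nor refuted para to a large group, and neither the size nor the direction of any effect there is known.

Going by these compounds, whether an amine or a carboxylic acid in place of the methoxy of compound 4 would give a readable value stays open. Also open, on these data alone, is how a longer chain in place of the methoxy of compound 2 would read.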